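Sulfonylamino in place of hydroxymethyl: outlook for compound 3

The compounds below may be only part of what the source reports. "The series", "measured", "known", "first", "only" and "open" are said of these compounds alone.

Measured so far:
compound 1 `O=C1O[C@H]([C@@H](O)Cn2cc(CNS(=O)(=O)c3ccc(Cl)cc3)nn2)C(OCc2ccccc2)=C1OCc1ccccc1` gives 13600 nM in a functional assay on HeLa cells (Homo sapiens) for antiproliferative activity, read by MTT assay, with a stated time of 72 h; a lower number here means a stronger inhibitor, a higher number a weaker inhibitor
compound 2 `O=C1O[C@H]([C@@H](O)Cn2cc(CCO)nn2)C(OCc2ccccc2)=C1OCc1ccccc1` gives 68800 nM in this assay

For the measured compounds named here, compound 2 stands at the highest of the two numbers in this assay, and its only neighbour is compound 1, whose step to it, a 5.1-fold higher number from compound 1 to compound 2 (0.70 log units; beyond the scatter), lies beyond the scatter. Compound 3 `O=C1O[C@H]([C@@H](O)Cn2cc(CNS(=O)(=O)c3ccc(Cl)cc3F)nn2)C(OCc2ccccc2)=C1OCc1ccccc1` differs from compound 2 by ((4-chloro-2-fluorophenyl)sulfonyl)amino in place of hydroxymethyl on a saturated chain carbon bound to an aromatic carbon. Going by the values given here, the one step that bears on this change is a 5.1-fold higher number from compound 1 to compound 2 (0.70 log units; beyond the scatter), which is the same exchange run backwards, without the fluorine on the ring. That step is therefore expected to reverse: the number for compound 3 is estimated to fall by a 5.7-fold lower number from compound 2 to compound 3 (0.76 log units; beyond the scatter), back close to the level of compound 1. Among the compounds with values here, the added fluorine has no measured counterpart here, so its effect is left open. Compound 3 is estimated at 12000 nM in this assay, within a range of 4000 nM to 40000 nM.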

Compound 3, half-maximal inhibitory concentration: 20700 nM
For compound 3 the middle estimate is 1.7-fold (0.24 log units) below the measured one; low and high end bracket the measured number.
By their numbers in this assay, from the lowest: compounds 1 and 3 (each within the scatter of the next); then compound 2.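

In this assay, the lower number for a sulfonylamino group than for hydroxymethyl at this position is seen a second time, with a 3.3-fold lower number from compound 2 to compound 3 (0.52 log units; beyond the scatter), so it is not confined to the ((4-chlorophenyl)sulfonyl)amino group of compound 1. Fluoro in place of hydrogen on an aromatic carbon gives a 1.5-fold higher number from compound 1 to compound 3 (0.18 log units; within the scatter), so this change does not separate compound 1 from compound 3 in this assay. For the compounds shown here, both sulfonylamino compounds therefore differ from compound 2 by steps beyond the scatter, and no compound here goes against this.

On these data alone, it remains open which part of the larger group carries the difference from hydroxymethyl, and how an amine or a carboxylic acid would read on the same saturated chain carbon. No independent measurement is available to explain these differences.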